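Carboxy Group Replaces a Methoxyethyl Chain on the Amide

The compounds below may be only part of what the source reports. "The series", "measured", "known", "first", "only" and "open" are said of these compounds alone.

In an in vitro assay on BHK cells for inhibition of Glucagon receptor (Homo sapiens) (a lower number here means a stronger inhibitor, a higher number a weaker inhibitor), compound 1 `CCN(CC)C(=O)c1ccc(NC(=O)N(Cc2ccc(C(=O)NCCC(=O)O)cc2)[C@H]2CC[C@H](C(C)(C)C)CC2)cc1` gives 2430 nM. Compound 2 `COCCCNC(=O)c1ccc(CN(C(=O)Nc2ccc(OC(F)(F)F)cc2)C2CCC(C(C)(C)C)CC2)cc1` reaches only a limit of this assay, > 10000 nM, so no number is known for it (the limit of > 10000 nM in this assay, at which 1 of the 2 values shown sits). Compound 3 `CC(C)(C)C1CCC(N(Cc2ccc(C(=O)NCC(=O)O)cc2)C(=O)Nc2ccc(OC(F)(F)F)cc2)CC1` differs from compound 2 by carboxy in place of 2-methoxyethyl on a saturated chain carbon bound to an amide-type nitrogen. Compound 1, which also carries a carboxy group, reads 2430 nM in this assay. On that footing a step toward stronger inhibition is expected, an at least 4.0-fold lower number from compound 2 to compound 3 (0.60 log units; beyond the scatter), though a second limit reading cannot be ruled out. Compound 3 is therefore estimated at 2500 nM, within a range from 600 nM to 10000 nM.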

Compound 3, half-maximal inhibitory concentration: 1700 nM
Compound 3: middle estimate off by 1.5-fold (0.17 log units), on the high side, and the stated range covers the measured number.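

In this assay, carboxy in place of 2-methoxyethyl on a saturated chain carbon bound to an amide-type nitrogen turns an unquantified reading into a measured one, with an at least 5.8-fold lower number from compound 2 to compound 3 (0.76 log units; beyond the scatter). This position therefore tolerates carboxy, and the change improves inhibition. The true size of the step remains unknown because compound 2 stands at a limit: the limit of > 10000 nM in this assay, at which 1 of the 3 values shown sits.

The compounds shown do not separate the effect of the carboxylic acid from that of the shorter chain. Going by these compounds, how an amine, a primary amide or a longer chain ending in a carboxylic acid would read here remains open.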